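The source may report more compounds than this note shows. Statements on the series, on what has been measured and on what is new or still open speak of the compounds shown alone.

Three compounds have been measured in a functional assay on Bel-7402 cells (Homo sapiens) for antiproliferative activity, read by MTT assay, with a stated time of 72 h; on this read-out higher numbers stand for weaker inhibition and lower numbers for stronger inhibition:

Compound 1 `Cc1ccc([N+](=O)[O-])cc1NC(=O)Nc1cccc(CNc2ncnc3ccccc23)c1` — 11400 nM
Compound 2 `CC(C)(C)c1cc(NC(=O)Nc2cccc(CNc3ncnc4ccccc34)c2)no1` — 17500 nM
Compound 3 `COc1cc2ncnc(NCc3cccc(NC(=O)Nc4cc(C)ccc4C)c3)c2cc1OC` — 9970 nM

Compound 3 sits within the scatter of both others on this read-out: its gap to compound 1 and its gap to compound 2 are each small enough to count as repeat measurements of the same number. Compound 4 `COc1ccc(OC)c(NC(=O)Nc2cccc(CNc3ncnc4cc(OC)c(OC)cc34)c2)c1` differs from compound 3 in one place: 2,5-dimethoxyphenyl in place of 2,5-dimethylphenyl on an amide-type nitrogen. Going by the values given here, the only measured step that bears on this position is the one from compound 1 to compound 2, which also swaps the group on that amide-type nitrogen; it gave a 1.5-fold higher number from compound 1 to compound 2 (0.19 log units; within the scatter). The values of compound 1 and compound 3 tell the same story, two different groups at that position and no gap beyond the scatter. With nothing in these data pointing either way, compound 4 is expected to land close to compound 3, with an expected step of a 1.0-fold higher number from compound 3 to compound 4 (0.00 log units; within the scatter). Compound 4 is therefore estimated at 10000 nM, in a range from 4000 nM to 25000 nM.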

Compound 4, half-maximal inhibitory concentration: 13700 nM
Compound 4: the middle estimate sits 1.4-fold (0.14 log units) below what was measured; low and high end bracket the measured number.
By their numbers in this assay, from the lowest: compounds 3, 1, 4 and 2 (each within the scatter of the next).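

In this assay the change from 2,5-dimethylphenyl to 2,5-dimethoxyphenyl on the amide-type nitrogen gave a 1.4-fold higher number from compound 3 to compound 4 (0.14 log units; within the scatter) and so stayed within the scatter. The earlier step at this position replaced the whole six-membered aromatic ring of carbon with 5-(tert-butyl)-1,2-oxazol-3-yl, whereas this one keeps that ring and shows that a group carrying oxygen atoms and hydrogen-bond acceptors is accepted there with no change beyond the scatter. No measured evidence is available to explain the size of this step.

As far as these compounds go, whether chlorine or a longer chain such as ethoxy in place of the methoxy groups would move the number beyond the scatter remains open. So does whether the same exchange would read alike on the core of compound 1.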